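This account rests on a few compounds, and the source may have more. Where it says the series, first, only, none or still open, it means among the compounds named here.

Compound 1 `COc1ccc2[nH]c(-c3ccccc3F)cc(=O)c2c1OC`: in a functional assay on HCT-116 cells (Homo sapiens) for cytotoxicity, read by MTT assay, with a stated time of 48 h (on this read-out higher numbers stand for weaker inhibition and lower numbers for stronger inhibition), compound 1 gives only a limit, > 20000 nM.
Compound 2 `COc1ccc2[nH]c(-c3ccc(F)cc3)cc(=O)c2c1OC`: in this assay compound 2 also gives only a limit, > 20000 nM.

Compound 1 therefore stands at the limit of this assay, and nothing finer than that is known of it. Among the measured compounds shown here, the single measured step, a step that the two limits leave unreadable from compound 1 to compound 2, cannot be read because of the limit of > 20000 nM in this assay, at which 2 of the 2 values shown sit; both ends of it sit at the same limit, so its size and direction stay hidden.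

Compound 3 `COc1ccc2[nH]c(-c3ccccc3F)cc(=O)c2c1O` differs from compound 1 by hydrogen in place of methyl on an oxygen on an aromatic ring. For the measured compounds named here, no measured step touches this oxygen, and the one step that exists is unreadable, so there is no measured basis for expecting a shift of any particular size in this assay. With both measured compounds at the limit, the most that can be said is that compound 3 is expected to sit near that same limit, with a modest chance of a readable number. On that basis compound 3 is estimated at 20000 nM, within a range of 5000 nM to 60000 nM. The step this implies, a number no higher from compound 1 to compound 3 (the limit leaves the size open), is expected to be none beyond the scatter.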

Compound 3, half-maximal inhibitory concentration: 50 nM
Estimate against measurement, compound 3: 400-fold (2.60 log units) above, and the stated range ends above it.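

In this assay, among the compounds shown here, methoxy to hydroxy on an oxygen on an aromatic ring gives an at least 400-fold lower number from compound 1 to compound 3 (2.60 log units; beyond the scatter), the first step whose size can be read, and it lies beyond the scatter. This oxygen is thus a place where one small change brings the compound off the limit and into a measurable range, something the swap from 2-fluorophenyl to 4-fluorophenyl could not reveal. The earlier pair could show nothing of the kind, and their step stays unreadable, because both compounds sit at one and the same limit: the limit of > 20000 nM in this assay, at which 2 of the 3 values shown sit.

Compound 3 gives 50 nM. As far as these compounds go, it remains open whether an ethoxy group, a longer chain or an acetate ester on this oxygen would keep a number close to that of compound 3 or would return to the limit. Also open, from the compounds shown here alone, is whether the same change would give a step of similar size in compound 2, with its 4-fluorophenyl group, and what hydroxy in place of the remaining methoxy would do in this assay.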